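The compounds below may be only part of what the source reports. "The series", "measured", "known", "first", "only" and "open" are said of these compounds alone.

In an ADME assay on MDBK cells (Bos taurus) for cytotoxicity (a lower number here means that less compound is tolerated, a higher number that more compound is tolerated), compound 1 (`Cc1ccc(Cn2ccc3nc(-c4ccccc4)nc-3c2)cc1`) gives > 100000 nM as a limit of the assay and not a number. Compound 2 (`Clc1ccc(Cn2ccc3nc(-c4ccccc4)nc-3c2)cc1`) likewise gives > 100000 nM as a limit only. Among the measured compounds shown here, compound 3 (`Brc1ccc(Cn2ccc3nc(-c4ccccc4)nc-3c2)cc1`) gives 83000 nM in this assay and this is the only true number among the three.

Compound 4 (`c1ccc(-c2ccc(Cn3ccc4nc(-c5ccccc5)nc-4c3)cc2)cc1`) has not yet been measured. It differs from compound 3 by phenyl in place of bromo on an aromatic carbon, para to a large group (phenyl in place of bromo on an aromatic carbon). For the measured compounds named here, two measured steps concern the same place (an at least 1.2-fold lower number from compound 1 to compound 3 (0.08 log units; that floor lies within the scatter)) and (an at least 1.2-fold lower number from compound 2 to compound 3 (0.08 log units; that floor lies within the scatter)). Each gives only a floor, and that floor lies within the scatter. The remaining step (a step that the two limits leave unreadable from compound 1 to compound 2) gives no readable size. None of these steps brings a ring to this place, so they offer only weak guidance for compound 4.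

Given those small floors, the estimated change (a 1.2-fold lower number from compound 3 to compound 4 (0.07 log units; within the scatter)) is not expected to go beyond the scatter in this assay in either direction. Compound 4 is expected to read 70000 nM with an estimated range from 30000 nM to 150000 nM. Compound 4 may also turn out as a limit of the assay and not a number.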

Compound 4, half-maximal cytotoxic concentration: 18000 nM
The estimate for compound 4 lay 3.9-fold (0.59 log units) above the measured number, outside the stated range (below it).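

In this assay, among the compounds shown here, phenyl in place of bromo on an aromatic carbon, para to a large group, gives a 4.6-fold lower number from compound 3 to compound 4 (0.66 log units; beyond the scatter), the first step at this position that is beyond the scatter and the first that brings a ring here. Phenyl in place of chloro gives an at least 5.5-fold lower number from compound 2 to compound 4 (0.74 log units; beyond the scatter), and phenyl in place of methyl gives an at least 5.5-fold lower number from compound 1 to compound 4 (0.74 log units; beyond the scatter), so the number at this position does respond to the group placed there, which the steps among methyl, chloro and bromo did not show. These last two steps give only floors, because compound 1 and compound 2 each stand at a limit of the assay and not at a number: the limit of > 100000 nM in this assay, at which 2 of the 4 values shown sit.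

Phenyl is the only ring shown at this position, so the compounds leave open whether the drop in this assay goes with an aromatic ring as such or simply with a group of more heavy atoms. A cyclohexyl ring, a pyridine ring or a longer alkyl chain at the same place could separate these two readings, and an amine would show whether a group that carries a charge behaves any differently here.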